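The source may report more compounds than this note shows. Statements on the series, on what has been measured and on what is new or still open speak of the compounds shown alone.

Among the compounds with values here, compound 2 `CC(C)C(c1ncc[nH]1)c1ccc(-c2ccc3cccc(F)c3c2)[nH]c1=O` gives 7.3 nM in an assay on CHO cells for displacement of a labelled ligand from prostaglandin E2 receptor EP3 subtype (Homo sapiens), read by radioligand binding (a higher number here means a weaker inhibitor, a lower number a stronger inhibitor), the lowest of the two numbers measured so far; compound 1 `CC(C)C(c1cnc(N)s1)c1ccc(-c2ccc3cccc(F)c3c2)[nH]c1=O` gives 16 nM, and the step of a 2.2-fold lower number from compound 1 to compound 2 (0.34 log units; beyond the scatter) is the only one recorded. Compound 3 `CC(C)C(c1ccc(-c2ccc3cccc(F)c3c2)[nH]c1=O)N1CCNC1=O` carries the change (2-oxoimidazolidin-1-yl in place of 1H-imidazol-2-yl on a saturated chain carbon bound to an aromatic carbon and a saturated chain carbon). Within the data shown here, that earlier step exchanged one five-membered aromatic ring for another, whereas no measured step replaces an aromatic ring with a non-aromatic one, so a loss of a similar modest order is expected rather than a gain, a 2.7-fold higher number from compound 2 to compound 3 (0.44 log units; beyond the scatter). For compound 3 the estimate in this assay is 20 nM, ranging from 5 nM to 80 nM.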

Compound 3, inhibition constant: 9.1 nM
The estimate for compound 3 lay 2.2-fold (0.34 log units) above the measured number; the measured number falls inside the stated range.
By their numbers in this assay, from the lowest: compounds 2, 3 and 1 (each within the scatter of the next, the first and the last beyond it).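

In this assay the saturated chain carbon carries a non-aromatic ring as well as an aromatic one: 2-oxoimidazolidin-1-yl for 1H-imidazol-2-yl gives a 1.2-fold higher number from compound 2 to compound 3 (0.10 log units; within the scatter) and 2-oxoimidazolidin-1-yl for 2-amino-1,3-thiazol-5-yl gives a 1.8-fold lower number from compound 1 to compound 3 (0.25 log units; within the scatter) in the same series. Across compounds 1, 2 and 3, then, an aromatic ring at this place is not required for a number in this range. No supporting data bear on why this is so.

As far as these compounds go, whether any ring is needed on this carbon stays open, as does how an open-chain urea, a primary amine or a carboxylic acid would read there.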